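Inverting a chain stereocentre at the half-life limit

The compounds below may be only part of what the source reports. "The series", "measured", "known", "first", "only" and "open" are said of these compounds alone.

Compound 1 (`O=C(O)[C@@H](CO)NC(=O)[C@H]1C[C@@H](O)CN1`): > 12 h
Compound 2 (`O=C(N[C@H](CO)C(=O)O)[C@@H]1C[C@H](O)CN1`): > 12 h

In an ADME assay on Caco-2 cells (Homo sapiens) for metabolic stability, read by HPLC, with a stated time of 12 h (on this read-out higher numbers stand for a longer-lived compound and lower numbers for a shorter-lived compound), compound 2 gives > 12 h, which is a limit and not a number. Compound 1 also gives a limit, > 12 h, in this assay. Both measured compounds therefore rest on (the limit of > 12 h in this assay, at which 2 of the 2 values shown sit), and neither has a readable position. Compound 3 (`O=C(O)[C@H](CO)NC(=O)[C@@H]1C[C@H](O)CN1`) departs from compound 2 in one respect: the two compounds have the same atoms and bonds and differ only in configuration as drawn: 1 of 3 stereo elements differ; a stereocentre at a saturated chain carbon is drawn R in compound 2 and S in compound 3. Among the compounds with values here, the only measured step that bears on this is a step that the two limits leave unreadable from compound 1 to compound 2, and it offers no size to carry over. It does show that the fact that compounds 1 and 2 differ only in the configuration as drawn left both compounds at the limit, though at ring stereocentres rather than the chain one. No change beyond the scatter is therefore expected in this assay, and no direction can be named. The expected step is a step that the limit leaves unreadable from compound 2 to compound 3 in this estimate. Compound 3 is estimated at 16 h, with 9 h to 30 h as the expected range.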

Compound 3, half-life: > 12 h
Compound 3 was reported as a limit; the forecaster's own chance of this, stated with the estimate: 85%; the middle value is on the limit's open side.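

Compound 3 gives only a limit in this assay, as do compound 1 and compound 2, so no step among these three compounds can be read. The compounds shown leave open how long any of them lasts in this assay, and whether configuration at any stereocentre alters half-life.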